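Compound 4 and a cytotoxicity limit

A few compounds are considered here, and "the series" means these few. Any claim that something is new, unique, unknown or untested is made for them only; others in the source may bear on it.

Measured in a toxicity assay on NIH3T3 cells (Mus musculus) for cytotoxicity, read by resazurin assay; on this read-out higher numbers stand for an effect only at larger amounts of compound and lower numbers for an effect already at smaller amounts:
- compound 1 `COC(=O)c1ccc(NCc2cncn2Cc2cccc([N+](=O)[O-])c2)cc1-c1ccccc1`: > 10000 nM
- compound 2 `COC(=O)c1ccc(NCc2cncn2Cc2ccc(OC)cc2)cc1-c1ccccc1`: "not determined" (no result reported)
- compound 3 `COC(=O)c1ccc(NCc2cncn2Cc2cccc(-c3ccccc3)c2)cc1-c1ccccc1`: "not determined" (no result reported)

Compound 1 shows > 10000 nM, which is a limit of the assay and not a number. Compound 3 stands at "not determined" (no result reported), so it offers no number to start from. The same is true of the other two entries, since one is a limit and the other is empty.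

Compound 4 `COC(=O)c1ccc(NCc2cncn2Cc2ccc(C#N)cc2)cc1-c1ccccc1` has not yet been measured. The change is 4-cyanophenyl in place of 3-phenylphenyl on a saturated chain carbon bound to an aromatic nitrogen.

Among the compounds with values here, no measured step shows what such a change does in this assay. Compound 4 is therefore expected to lie in the same region as compound 1, with no step beyond the scatter in either direction. That expectation rests on compound 1 alone, whose > 10000 nM is again a limit. The assay may well report only a limit for compound 4 too. The estimated value for compound 4 is 20000 nM, in an expected range from 6000 nM to 60000 nM.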

Compound 4, half-maximal effective concentration: > 10000 nM
Compound 4: a limit, no number (the forecaster's own chance of this, stated with the estimate: 75%); the middle value is on the limit's open side.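

No step can be read from compound 1 to compound 4, since each result is a limit of the assay and not a number: the limit of > 10000 nM in this assay, at which 2 of the 4 values shown sit.

The compounds shown leave open what amount of compound 1 or compound 4 would produce an effect in this assay, and whether 4-cyanophenyl in place of 3-nitrophenyl changes that amount.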